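Aryl sulfonamide series: ethyl in place of two methyls

The source may report more compounds than this note shows. Statements on the series, on what has been measured and on what is new or still open speak of the compounds shown alone.

Compound 3 `Cc1cc(C)cc(NS(=O)(=O)c2ccc(N3CCNC3=O)cc2)c1` holds the lowest number among the three measured compounds in a functional assay on MCF7 cells (Homo sapiens) for antiproliferative activity, read by sulforhodamine B assay, with a stated time of 48 h (on this read-out higher numbers stand for weaker inhibition and lower numbers for stronger inhibition), where compound 3 gives 100 nM. Compound 2 `COc1cccc(NS(=O)(=O)c2ccc(N3CCNC3=O)cc2)c1` gives 120 nM in this assay, and the step of a 1.2-fold lower number from compound 2 to compound 3 (0.08 log units; within the scatter). Compound 1 `O=C1NCCN1c1ccc(S(=O)(=O)Nc2ccc(F)c(F)c2)cc1` gives 620 nM in this assay; the steps of a 5.2-fold lower number from compound 1 to compound 2 (0.71 log units; beyond the scatter) and a 6.2-fold lower number from compound 1 to compound 3 (0.79 log units; beyond the scatter) are the only ones beyond the scatter, and both swap the ring with two fluorines for a ring without fluorine.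

Compound 4 `CCc1cccc(NS(=O)(=O)c2ccc(N3CCNC3=O)cc2)c1` is not yet measured in this assay. The change from compound 3 to compound 4 is 3-ethylphenyl in place of 3,5-dimethylphenyl on a sulfonamide nitrogen. Within the data shown here, the step that bears most on it is the one from compound 2 to compound 3, which also exchanges one fluorine-free ring for another and stayed within the scatter. The steps from compound 1 do not apply here, since compound 4 keeps a ring without fluorine. A step within the scatter is therefore expected, with the estimate for compound 4 taken as a 1.3-fold higher number from compound 3 to compound 4 (0.11 log units; within the scatter). Compound 4 is expected to give about 130 nM in this assay, within a range from 60 nM to 280 nM.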

Compound 4, half-maximal inhibitory concentration: 130 nM
Beside the measured number, compound 4's estimate shows no gap at the digits printed; measured number inside the range.
By their numbers in this assay, from the lowest: compounds 3, 2 and 4 (each within the scatter of the next); then compound 1.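

Within this assay, the 3-ethylphenyl and 3,5-dimethylphenyl groups on the sulfonamide nitrogen both count 8 heavy atoms, all carbon, and rearranging those atoms leaves the result within the scatter (a 1.3-fold higher number from compound 3 to compound 4 (0.11 log units; within the scatter)). Ethyl in place of methoxy on an aromatic carbon also stays within the scatter (a 1.1-fold higher number from compound 2 to compound 4 (0.03 log units; within the scatter)), so this assay does not separate these two groups. Compound 4 joins compound 2 and compound 3 as a third fluorine-free compound lying beyond the scatter from the 3,4-difluorophenyl compound (a 4.8-fold lower number from compound 1 to compound 4 (0.68 log units; beyond the scatter)), with no listed compound going against this.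

Going by these compounds, whether an amine, a carboxylic acid or a longer chain such as hexyl on this ring would stay in the same range remains open. Nothing available gives a cause for any of these steps.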